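The source may report more compounds than this note shows. Statements on the series, on what has been measured and on what is new or still open speak of the compounds shown alone.

Measured so far:
compound 1, `CCOc1ncc(-c2nc(C(F)(F)F)sc2N2CCN(C(=O)Cn3cnc4ccccc43)[C@H](C)C2)cn1`: 49 nM
compound 2, `CCOc1ncc(-c2nc(C(F)(F)F)sc2N2CCN(C(=O)Cn3nccc3C)[C@H](C)C2)cn1`: 162 nM

Both compounds share one core and differ only in the aromatic group on the saturated chain carbon bound to the carbonyl carbon. In a functional assay on U2OS cells for antagonist activity at C-X-C chemokine receptor type 3 (Homo sapiens), read by beta-arrestin recruitment (a higher number here means a weaker inhibitor, a lower number a stronger inhibitor), compound 1 gives 49 nM, and compound 2 gives 162 nM. Among the compounds with values here, the single step measured so far is a 3.3-fold higher number from compound 1 to compound 2 (0.52 log units; beyond the scatter). Compound 2 thus stands at the higher of the two numbers, set apart from compound 1 by a step beyond the scatter.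

Compound 3, `CCOc1ncc(-c2nc(C(F)(F)F)sc2N2CCN(C(=O)Cn3ccc(C(F)(F)F)n3)[C@H](C)C2)cn1`, has not been measured in this assay. The change from compound 2 is 3-(trifluoromethyl)-1H-pyrazol-1-yl in place of 5-methyl-1H-pyrazol-1-yl on a saturated chain carbon bound to a carbonyl carbon. Within the data shown here, no measured step covers this kind of exchange: the one step in hand swaps a bicyclic aromatic group for the methylpyrazole, not one pyrazole substituent for another. Among the measured compounds shown here, the only guidance is that the pyrazole compound 2 sits at the high end in this assay, and the exchange of methyl for trifluoromethyl on the same ring does not alter the donor or acceptor count. The expected step is a 1.1-fold lower number from compound 2 to compound 3 (0.03 log units; within the scatter), small and possibly within the scatter. Compound 3 is therefore estimated at 150 nM, with a range from 50 nM to 450 nM.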

Compound 3, half-maximal inhibitory concentration: 93 nM
The estimate for compound 3 lay 1.6-fold (0.21 log units) above the measured number; the range from low to high includes it.
By their numbers in this assay, from the lowest: compounds 1, 3 and 2 (each within the scatter of the next, the first and the last beyond it).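

In this assay, the exchange of 5-methyl-1H-pyrazol-1-yl for 3-(trifluoromethyl)-1H-pyrazol-1-yl on a saturated chain carbon bound to a carbonyl carbon gives a 1.7-fold lower number from compound 2 to compound 3 (0.24 log units; within the scatter) and so leaves the two pyrazoles unseparated, even with the entering group carrying more heavy atoms. The bicyclic 1H-benzimidazol-1-yl stood clear of the methylpyrazole at a 3.3-fold higher number from compound 1 to compound 2 (0.52 log units; beyond the scatter) but not of the trifluoromethylpyrazole at a 1.9-fold higher number from compound 1 to compound 3 (0.28 log units; within the scatter) in this series, so a single five-membered aromatic ring at this position is not by itself enough to set a compound apart from compound 1. No independent data bear on this result, and the reading goes no further than the numbers.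

The two pyrazoles differ in both the substituent and its ring position, so 3-methyl-1H-pyrazol-1-yl or 5-(trifluoromethyl)-1H-pyrazol-1-yl would be needed to separate these two changes. The compounds shown also leave open how this position responds to a non-aromatic group such as a simple amine or a carboxylic acid in place of the aromatic ring.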